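Compound 4: a new group at the chain end

This account rests on a few compounds, and the source may have more. Where it says the series, first, only, none or still open, it means among the compounds named here.

Compound 1 `COc1cc2c(Nc3ccc(C#N)cc3)ncnc2cc1OCCCN1CCC(O)CC1`: > 100000 nM
Compound 2 `COc1cc2c(Nc3ccc(C#N)cc3)ncnc2cc1OCCCN1CCC(c2ccccc2)CC1`: 9800 nM
Compound 3 `COc1cc2c(Nc3ccc(C#N)cc3)ncnc2cc1OCCCN1CCC(N(C)C)CC1`: 31000 nM

These three compounds were tested in a functional assay on MCF7 cells (Homo sapiens) for antiproliferative activity, read by MTT assay, with a stated time of 72 h; on this read-out higher numbers stand for weaker inhibition and lower numbers for stronger inhibition. The entry for compound 1 , > 100000 nM, is a limit of the assay and not a number. Of the two true numbers, the higher belongs to compound 3 at 31000 nM, and the gap to the other is a 3.2-fold higher number from compound 2 to compound 3 (0.50 log units; beyond the scatter).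

Compound 4 `CCN1CCN(CCCOc2cc3ncnc(Nc4ccc(C#N)cc4)c3cc2OC)CC1` has not yet been measured. It differs from compound 3 as follows: 4-ethylpiperazin-1-yl in place of 4-(dimethylamino)piperidin-1-yl on a saturated chain carbon, three bonds along the chain from an oxygen on an aromatic ring. In words, 4-ethylpiperazin-1-yl stands in place of 4-(dimethylamino)piperidin-1-yl on a saturated chain carbon, three bonds along the chain from an oxygen on an aromatic ring.

Going by the values given here, no measured step makes this exchange. The nearest ones swap a group on a saturated ring carbon. Two of them, an at least 10-fold lower number from compound 1 to compound 2 (1.00 log units; beyond the scatter) and an at least 3.2-fold lower number from compound 1 to compound 3 (0.50 log units; beyond the scatter), start from the limit of > 100000 nM in this assay, at which 1 of the 3 values shown sits, and so give no exact size. Among the compounds with values here, the only step between true numbers is the modest 3.2-fold higher number from compound 2 to compound 3 (0.50 log units; beyond the scatter), and it offers no firm direction for the new exchange.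

Little change is therefore expected in this assay, and the expected step is a 1.2-fold lower number from compound 3 to compound 4 (0.09 log units; within the scatter). Compound 4 is estimated at 25000 nM, with an expected range from 8000 nM to 80000 nM.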

Compound 4, half-maximal inhibitory concentration: 29900 nM
For compound 4 the middle estimate is 1.2-fold (0.08 log units) below the measured one; the measured number falls inside the stated range.
By their numbers in this assay, from the lowest: compound 2; then compounds 4 and 3 (each within the scatter of the next). At a limit, above all of these: compound 1.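

In this assay, going by these compounds alone, the step of a 1.0-fold lower number from compound 3 to compound 4 (0.02 log units; within the scatter) is the first exchange of a whole group at this place, on a saturated chain carbon, three bonds along the chain from an oxygen on an aromatic ring, and it leaves 4-(dimethylamino)piperidin-1-yl and 4-ethylpiperazin-1-yl indistinguishable here, although the two rings carry different numbers of hetero atoms. The step of a 3.1-fold higher number from compound 2 to compound 4 (0.48 log units; beyond the scatter) is about the same size as the one already seen with the dimethylamino group, so 4-phenylpiperidin-1-yl keeps the lowest number among the compounds shown, now against two different groups that carry a second nitrogen. The step of an at least 3.3-fold lower number from compound 1 to compound 4 (0.52 log units; beyond the scatter) starts from a limit of the assay for its first compound, not from a number, and it gives no exact size: the limit of > 100000 nM in this assay, at which 1 of the 4 values shown sits.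

The compounds shown leave open whether the low number of compound 2 follows the phenyl ring itself, which 4-phenylpiperazin-1-yl at the same place would test. They also leave open whether morpholin-4-yl, or a longer chain carrying 4-ethylpiperazin-1-yl, would read the same in this assay.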